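A few compounds are considered here, and "the series" means these few. Any claim that something is new, unique, unknown or untested is made for them only; others in the source may bear on it.

Measured compounds:
Compound 1: `CCOC(=O)c1ccc(OC(=O)c2ccc3c(c2)C(C)(C)CCN3C)cc1` — 1130 nM
Compound 2: `CCOC(=O)c1ccc(OC(=O)c2cc3c(cc2C)N(C)CCC3(C)C)cc1` — 796 nM

Among the measured compounds shown here, in a functional assay on CV-1 cells for activation of retinoic acid receptor alpha (Homo sapiens) (a higher number here means that more compound is needed for the effect, a lower number that less compound is needed), compound 1 stands at the higher of the two numbers, with compound 2 the only neighbour; the step of a 1.4-fold lower number from compound 1 to compound 2 (0.15 log units; within the scatter) does not reach beyond the scatter, so the two compounds are not told apart.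

Compound 3 is `CCOC(=O)c1ccc(OC(=O)c2ccc3c(c2)C(C)(C)CCN3C(C)C)cc1`. Against compound 1 the change is isopropyl in place of methyl on a nitrogen on an aromatic ring in a ring. For the measured compounds named here, no measured step touches this position; the single step in hand, a 1.4-fold lower number from compound 1 to compound 2 (0.15 log units; within the scatter), concerns a methyl on an aromatic carbon and was itself within the scatter. There is therefore no shown ground for expecting a step in this assay in either direction beyond the scatter, and the estimate for compound 3 stays near the number of compound 1, as a 1.1-fold lower number from compound 1 to compound 3 (0.05 log units; within the scatter). Going by the values given here, compound 3 is accordingly expected at about 1000 nM, within 350 nM to 3000 nM, with a wide range because only one neighbour is known.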

Compound 3, half-maximal effective concentration: 217 nM
The estimate for compound 3 lay 4.6-fold (0.66 log units) above the measured number; the measured number lies below the stated range.
By their numbers in this assay, from the lowest: compound 3; then compounds 2 and 1 (each within the scatter of the next).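

In this assay, isopropyl in place of methyl on the nitrogen gives a 5.2-fold lower number from compound 1 to compound 3 (0.72 log units; beyond the scatter), so this position responds to its substituent in a way that the earlier step, on an aromatic carbon, did not show. The change involves carbon alone, as neither group carries a hydrogen-bond donor, a hydrogen-bond acceptor or a net charge. Nothing at hand explains why this step is as large as it is.

From the compounds shown here alone, with only methyl and isopropyl on this nitrogen, it remains open whether an ethyl, a cyclopropyl or a tert-butyl group would fall on the same trend or whether isopropyl is a special case. Also open, going by these compounds, is how the isopropyl compound would respond to a methyl on the aromatic carbon, or to a carboxylic acid in place of the ethyl ester.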